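The source may hold more compounds than are shown below. What is called first, only, known or untested is meant among the compounds shown, and "the series" means these compounds.

Measured compounds:

Compound 1, `COc1cc(-c2nn(-c3cccc(NC(=O)Nc4cccc(C(F)(F)F)c4)c3)cc2-c2ccncc2)ccc1Cl`, 2700 nM
Compound 2, `COc1cc(-c2nn(-c3cccc(NC(=O)Nc4ccc(Cl)c(C(F)(F)F)c4)c3)cc2-c2ccncc2)ccc1Cl`, 5870 nM

Both numbers come from a functional assay on OVCAR-8 cells (Homo sapiens) for inhibition, read by sulforhodamine B assay, with a stated time of 48 h; a higher number here means a weaker inhibitor of growth, a lower number a stronger inhibitor of growth. Among the measured compounds shown here, compound 2 stands at the higher of the two values, with compound 1 as its only neighbour: the step of a 2.2-fold higher number from compound 1 to compound 2 (0.34 log units; beyond the scatter) is described as modest and lies beyond the usual scatter of repeated measurements.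

The next compound, compound 3, is `O=C(Nc1cccc(-n2cc(-c3ccncc3)c(-c3ccc(Cl)c(O)c3)n2)c1)Nc1ccc(Cl)c(C(F)(F)F)c1`. Relative to compound 2 the change is hydrogen in place of methyl on an oxygen on an aromatic ring. For the measured compounds named here, no measured step speaks to this change. Going by the values given here, the single step that has been measured, from compound 1 to compound 2, concerns chloro in place of hydrogen on an aromatic carbon of the urea-bearing aryl group, and leaves the methoxy untouched; it therefore says nothing about what hydrogen in place of methyl on the oxygen will do. With nothing in the record to guide the direction, the step of a 1.1-fold lower number from compound 2 to compound 3 (0.03 log units; within the scatter) is expected to stay within or near the scatter. Compound 3 is therefore estimated at 5500 nM in this assay, with a range from 2000 nM to 15000 nM.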

Compound 3, concentration for total growth inhibition: 2280 nM
The estimate for compound 3 lay 2.4-fold (0.38 log units) above the measured number; the measured number falls inside the stated range.
By their numbers in this assay, from the lowest: compounds 3 and 1 (each within the scatter of the next); then compound 2.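

In this assay, among the compounds shown here, replacing methoxy with hydroxy on the 4-chloro-3-methoxyphenyl group gives a 2.6-fold lower number from compound 2 to compound 3 (0.41 log units; beyond the scatter), which shows for the first time that this oxygen substituent affects the read-out. The earlier step, a 2.2-fold higher number from compound 1 to compound 2 (0.34 log units; beyond the scatter), involved a chloro on the urea-bearing aryl group and left this group untouched, so it could not show this. The new step runs in the direction of stronger growth inhibition and is modest in size, though beyond the scatter, and the data available offer no explanation for it.

This single pair cannot show whether an ethoxy group or an amine in place of the hydroxy would continue the same trend or reverse it. Going by these compounds, it also remains open whether methoxy to hydroxy would produce a step of the same direction and size on compound 1, which lacks the chloro on the urea-bearing aryl group.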